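Triazole-linked lactams: swapping a hydroxyphenyl for a cyanophenyl

This account rests on a few compounds, and the source may have more. Where it says the series, first, only, none or still open, it means among the compounds named here.

Three compounds share one core, a bicyclic lactam carrying a triazole whose aromatic nitrogen bears a substituted phenyl ring. Compound 1 `CC1(C)[C@H]2CC[C@]1(C)N(Cc1cn(-c3cccc(Cl)c3)nn1)C(=O)C2` carries a 3-chlorophenyl there, compound 2 `CC1(C)[C@H]2CC[C@]1(C)N(Cc1cn(-c3ccccc3O)nn1)C(=O)C2` a 2-hydroxyphenyl, and compound 3 `COc1ccc(-n2cc(CN3C(=O)C[C@@H]4CC[C@@]3(C)C4(C)C)nn2)cc1` a 4-methoxyphenyl. In a functional assay on LoVo cells (Homo sapiens) for inhibition, read by MTT assay, with a stated time of 24 h (on this read-out higher numbers stand for weaker inhibition and lower numbers for stronger inhibition), compound 1 gives 70 nM, compound 2 gives 540 nM, and compound 3 gives 70 nM. Compound 2 therefore stands at the highest of the three numbers, the weakest inhibitor of the set, since a 7.7-fold higher number from compound 1 to compound 2 (0.89 log units; beyond the scatter) and a 7.7-fold lower number from compound 2 to compound 3 (0.89 log units; beyond the scatter), while no change at the digits printed from compound 1 to compound 3 (within the scatter).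

Compound 4 `CC1(C)[C@H]2CC[C@]1(C)N(Cc1cn(-c3cccc(C#N)c3)nn1)C(=O)C2` is not yet measured. It differs from compound 2 in one place: 3-cyanophenyl in place of 2-hydroxyphenyl on an aromatic nitrogen. Both steps away from the 2-hydroxyphenyl, toward 3-chlorophenyl and toward 4-methoxyphenyl, lowered the number by a modest amount and beyond the scatter, and the two replacements agree with each other closely. A cyano group on the phenyl ring is a third variant in the same position class, so a similar gain is expected. Compound 4 is estimated at 90 nM, within 40 nM to 250 nM, which corresponds to an expected step of a 6.0-fold lower number from compound 2 to compound 4 (0.78 log units; beyond the scatter) in this assay.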

Compound 4, half-maximal inhibitory concentration: 320 nM
Compound 4: middle estimate off by 3.6-fold (0.55 log units), on the low side; measured number above the stated range.
By their numbers in this assay, from the lowest: compounds 1 and 3 (each within the scatter of the next); then compounds 4 and 2 (each within the scatter of the next).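

In this assay the 3-cyanophenyl does not bring the gain seen with the other two rings: the change gives a 1.7-fold lower number from compound 2 to compound 4 (0.23 log units; within the scatter) and so leaves compound 4 indistinguishable from compound 2. The clearer lesson comes from the matched pair that keeps the substituent in the same ring position and changes only the group, where cyano in place of chloro gives a 4.6-fold higher number from compound 1 to compound 4 (0.66 log units; beyond the scatter) and shows that this position responds to the identity of the group, not merely to removal of the 2-hydroxyphenyl; the comparison with the 4-methoxyphenyl agrees, with a 4.6-fold higher number from compound 3 to compound 4 (0.66 log units; beyond the scatter) as the step. No supporting measurement is available to explain why the nitrile and chloro groups differ here.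

The compounds shown leave open how an unsubstituted phenyl ring would compare. They also leave open whether a 3-aminophenyl or a phenyl ring bearing a carboxylic acid would sit nearer compound 1 or compound 4.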